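The source may hold more compounds than are shown below. What is called first, only, known or untested is meant among the compounds shown, and "the series" means these compounds.

Three compounds have been measured in a functional assay on OVCAR-8 cells (Homo sapiens) for inhibition, read by sulforhodamine B assay, with a stated time of 48 h; on this read-out lower numbers stand for stronger inhibition of growth and higher numbers for weaker inhibition of growth:

compound 1 `Nc1cc(N)c2nc(-c3ccccc3)c(Oc3ccc(Cl)c(Cl)c3)nc2c1`, with 28200 nM;
compound 2 `COc1ccc(Sc2nc3cc(N)cc(N)c3nc2-c2ccccc2)cc1`, for which only a limit is reported, < 100000 nM;
compound 3 `Nc1cc(N)c2nc(-c3ccccc3)c(Sc3ccc(Cl)c(Cl)c3)nc2c1`, with 24500 nM.

Among the two numbers shown, compound 3 sits closest to compound 1, and the step of a 1.2-fold lower number from compound 1 to compound 3 (0.06 log units; within the scatter) lies within the scatter. The steps a step that the limit leaves unreadable from compound 1 to compound 2 and a step that the limit leaves unreadable from compound 2 to compound 3 cannot be read in size because of the limit of < 100000 nM in this assay, at which 1 of the 3 values shown sits.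

Compound 4 `Nc1cc(N)c2nc(-c3ccccc3)c(Oc3ccc(F)cc3)nc2c1` has not yet been measured. It differs from compound 3 in one place: 4-fluorophenoxy in place of (3,4-dichlorophenyl)sulfanyl on an aromatic carbon. Two things change at once, the sulfur to an oxygen and the 3,4-dichlorophenyl to a 4-fluorophenyl. Only the first part has a readable precedent, the step of a 1.2-fold lower number from compound 1 to compound 3 (0.06 log units; within the scatter), which was within the scatter. Among the measured compounds shown here, for the exchange of the aryl substituents the only comparison is between compound 2 and compound 3, and there the limit for compound 2 leaves the size open. The expectation for compound 4 in this assay is therefore a step of a 1.6-fold higher number from compound 3 to compound 4 (0.21 log units; within the scatter), leaning towards a higher number but not clearly beyond the scatter. Compound 4 is estimated at 40000 nM, with a range from 12000 nM to 100000 nM.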

Compound 4, concentration for 50% growth inhibition: 22400 nM
The estimate for compound 4 lay 1.8-fold (0.25 log units) above the measured number, within the range that was stated.
By their numbers in this assay, from the lowest: compounds 4, 3 and 1 (each within the scatter of the next).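

With the oxygen held fixed, the exchange of 3,4-dichlorophenyl for 4-fluorophenyl can now be read on its own in this assay: it is a 1.3-fold lower number from compound 1 to compound 4 (0.10 log units; within the scatter). Even the double exchange, of sulfur for oxygen together with the change of aryl group, amounts only to a 1.1-fold lower number from compound 3 to compound 4 (0.04 log units; within the scatter). At this aromatic carbon next to the ring nitrogen, compounds 1, 3 and 4 therefore do not separate from one another, whichever of these linking atoms and aryl groups is present, although this holds only for these three compounds.

Compound 2 is reported only as a limit, and its steps to the other compounds cannot be read: the limit of < 100000 nM in this assay, at which 1 of the 4 values shown sits. Going by these compounds, whether an amine, a carboxylic acid or a longer chain at this carbon, in place of the substituted phenoxy or phenylsulfanyl groups, would move the number beyond the scatter stays open, as does the effect of any change to the neighbouring phenyl group or to the amino groups of the shared core.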